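Ring-substituent swap on the aryl ether, acid dissociation

A few compounds are considered here, and "the series" means these few. Any claim that something is new, unique, unknown or untested is made for them only; others in the source may bear on it.

Working notes on a small series of aminoquinoline-type compounds measured for a physicochemical assay for acid dissociation. Compound 1 `FC(F)(F)c1ccc(-c2ccc3c(NCCCNCc4ccco4)ccnc3c2)cc1` gives 9.47 in this assay. Compound 2 `COc1cccc(CNCCCNc2ccnc3cc(-c4ccc(F)cc4)ccc23)c1O` gives 9.47 in this assay. Compound 3 `COc1ccc(Oc2ccc3c(NCCCNCc4cc(F)ccc4OC)ccnc3c2)cc1` gives 9.28 in this assay; the numbers for compound 1 and compound 2 each lie within the scatter of it, so the three measured values cannot be separated. The unmeasured compound 4 `COc1cccc(Oc2ccc3c(NCCCNCc4cc(F)ccc4OC)ccnc3c2)c1` differs from compound 3 only in the outer aryl ether group: 3-methoxyphenyl in place of 4-methoxyphenyl on an oxygen on an aromatic ring. Among the compounds with values here, no measured pair differs in a single place, so no step is known. Across the three measured compounds the outer groups vary widely while the read-out stays flat, so the step of a number 0.02 log units higher from compound 3 to compound 4 (within the scatter) is expected to be none beyond the scatter, because compound 1 at 9.47 and compound 2 at 9.47 show no movement for larger changes. Compound 4 is therefore estimated at 9.3 in this assay, within a range from 9 to 9.6.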

Compound 4, acid dissociation constant: 9.28
Beside the measured number, compound 4's estimate is 0.02 log units above it, and the stated range covers the measured number.
By their numbers in this assay, from the lowest: compounds 3, 4, 1 and 2 (each within the scatter of the next).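

Within the data shown here, exchanging 4-methoxyphenyl for 3-methoxyphenyl on an oxygen on an aromatic ring gives, in this assay, no change at the digits printed from compound 3 to compound 4 (within the scatter), and this is the first reading for a change in one place. The earlier compounds shown here differed in several places at once, whereas this pair gives a direct reading for this position: with the same heavy atoms and the same donor and acceptor counts in the leaving and entering groups, moving the methoxy group does not separate the two compounds. No available evidence bears on the reason for this result.

The compounds shown leave open whether a different group on this aryl ether, such as a carboxylic acid or a dimethylamino group in place of the methoxy group, would take the read-out beyond the scatter. They also leave open whether the unsubstituted phenyl ether would stay within it.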